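This account rests on a few compounds, and the source may have more. Where it says the series, first, only, none or still open, it means among the compounds named here.

Measured so far in a functional assay on T47D cells (Homo sapiens) for inhibition, read by sulforhodamine B assay, with a stated time of 48 h, tested at 10 uM; on this read-out lower numbers stand for a stronger effect and higher numbers for a weaker effect at the one concentration tested:
- compound 1 `COc1cc2cc(Oc3ccc(NC(=O)Nc4ccccc4)cc3)c(C)nc2cc1OC`: compound 1 gives 97.1%
- compound 2 `COc1cc2cc(Oc3ccc(NC(=O)Nc4ccc(Cl)c(C(F)(F)F)c4)cc3)c(C)nc2cc1OC`: compound 2 gives 21.4%

Among the compounds with values here, compound 2 stands as the lower of the two numbers; the nearest measured compound is compound 1, and the only step in the set, a number 75.7 percentage points lower from compound 1 to compound 2 (beyond the scatter), separates them. Compound 3 `COc1cc2cc(Oc3ccc(NC(=O)Nc4ccc(Cl)c(Cl)c4)cc3)c(C)nc2cc1OC` is not yet measured. It differs from compound 2 by chloro in place of trifluoromethyl on an aromatic carbon, so that the 4-chloro-3-(trifluoromethyl)phenyl becomes 3,4-dichlorophenyl. No measured step bears directly on this exchange: the one step shown replaces phenyl with 4-chloro-3-(trifluoromethyl)phenyl, which is a much larger change than swapping trifluoromethyl for chloro while the 4-chloro remains. The expectation is therefore a step in this assay of about a number 8.6 percentage points higher from compound 2 to compound 3 (within the scatter), not clearly beyond the scatter, leaning slightly weaker. Compound 3 is estimated at 30%, with a range from 15% to 55%.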

Compound 3, a percentage reported as activity, at one concentration (the size of the read-out at that concentration, not a potency): 60.9%
For compound 3 the middle estimate is 30.9 percentage points below the measured one; the measured number lies above the stated range.
By their numbers in this assay, from the lowest: compound 2; then compound 3; then compound 1.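

In this assay, the group on this aromatic carbon, ortho to a chloro group, proves not to be interchangeable: chloro in place of trifluoromethyl gives a number 39.5 percentage points higher from compound 2 to compound 3 (beyond the scatter), a large step from this one place with the rest of the structure unchanged. The 3,4-dichlorophenyl still retains a gain over plain phenyl, with a number 36.2 percentage points lower from compound 1 to compound 3 (beyond the scatter), so part of the effect remains without the trifluoromethyl, while compound 2 stays the lowest of the three. Nothing available gives a reason for the difference between these two groups.

Still open, going by these compounds, is how a methoxy, a nitrile or an amine would read on this same carbon. Within the data shown here, also open is whether the trifluoromethyl keeps its effect without the chloro group, and the single-concentration read-out gives no potency for any compound.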